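Selenium replaced by sulfur on two bis-amide cores

The source may report more compounds than this note shows. Statements on the series, on what has been measured and on what is new or still open speak of the compounds shown alone.

Four compounds are compared for how strongly they kill a human colon cancer cell line. The read-out is a functional assay on HT-29 cells (Homo sapiens) for cytotoxicity, read by MTT assay, with a stated time of 72 h; on this read-out higher numbers stand for lower toxicity in this test and lower numbers for higher toxicity in this test. Compound 1 `C[Se]/C(=N\C(=O)c1cc2ccccc2s1)NC(=O)c1cc2ccccc2s1` and compound 2 `CS/C(=N\C(=O)c1cc2ccccc2s1)NC(=O)c1cc2ccccc2s1` share one core, and compound 3 `C[Se]/C(=N\C(=O)c1cnc2ccccc2c1)NC(=O)c1cnc2ccccc2c1` and compound 4 `CS/C(=N\C(=O)c1cnc2ccccc2c1)NC(=O)c1cnc2ccccc2c1` share another; the difference between the two cores is not broken down here.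

In this assay compound 1 gives > 100000 nM, which is a limit of the assay and not a number. Compound 2 gives 88200 nM in this assay. The step of an at least 1.1-fold lower number from compound 1 to compound 2 (0.05 log units; that floor lies within the scatter) is the structural change (a group of 2 heavy atoms (1 carbon, 1 sulfur; no ring) in place of a group of 2 heavy atoms (1 carbon, 1 selenium; no ring), on a carbon with a double bond to nitrogen). Compound 3 gives > 100000 nM in this assay, again a limit of the assay rather than a number.

The same change is made from compound 3 to compound 4, namely (a group of 2 heavy atoms (1 carbon, 1 sulfur; no ring) in place of a group of 2 heavy atoms (1 carbon, 1 selenium; no ring), on a carbon with a double bond to nitrogen). Two of the three values sit at the limit of > 100000 nM in this assay, at which 2 of the 3 values shown sit, so the measured step is itself only a floor. Compound 4 is expected to sit close to that floor. The expected step of an at least 1.0-fold lower number from compound 3 to compound 4 (0.02 log units; that floor lies within the scatter) rests on the measured step of an at least 1.1-fold lower number from compound 1 to compound 2 (0.05 log units; that floor lies within the scatter), which stayed within the usual scatter. Compound 4 is therefore estimated at 95000 nM, most likely between 50000 nM and 200000 nM, with a fair chance that this assay reports only a limit for compound 4.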

Compound 4, concentration lethal to 50% of the cells: > 100000 nM
Compound 4: a limit, no number; the forecaster's own chance of this, stated with the estimate: 55%; at least 1.0-fold (0.02 log units) between middle value and limit.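

Compound 3 and compound 4 both end at a limit of the assay rather than a number, so no step between them can be read in this assay: the limit of > 100000 nM in this assay, at which 3 of the 4 values shown sit.

The compounds shown leave open whether putting methylsulfanyl in place of the selenium-bearing group changes toxicity to these cells by a real amount on either core, and how toxic compound 1, compound 3 and compound 4 actually are.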